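Cyano to nitro on the aryl ring of compound 3

The source may report more compounds than this note shows. Statements on the series, on what has been measured and on what is new or still open speak of the compounds shown alone.

Compound 1, `Cc1ccc(-c2cs/c(=N/NC(=O)CSc3nnnn3C)n2-c2ccccc2)cc1`: 68.8%
Compound 2, `Cn1cnnc1SCC(=O)N/N=c1/scc(-c2ccc(C#N)cc2)n1-c1ccccc1`: 62.6%
Compound 3, `Cn1nnnc1SCC(=O)N/N=c1/scc(-c2ccc(C#N)cc2)n1-c1ccccc1`: 53.9%

These three numbers come from a functional assay on C6 cells (Rattus norvegicus) for cytotoxicity, read by MTT assay, with a stated time of 24 h, tested at 12 ug/mL; a higher number here means a weaker effect of the compound at the concentration tested, a lower number a stronger effect. Compound 3 holds the lowest of them, but only in part beyond the scatter: the step of a number 8.7 percentage points lower from compound 2 to compound 3 (within the scatter) is within the usual spread, so compound 2 and compound 3 cannot be ordered against each other, whereas the step of a number 14.9 percentage points lower from compound 1 to compound 3 (beyond the scatter) is beyond it and counts as a modest change.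

Compound 4, `Cn1nnnc1SCC(=O)N/N=c1/scc(-c2ccc([N+](=O)[O-])cc2)n1-c1ccccc1`, differs from compound 3 in a single place: nitro in place of cyano on an aromatic carbon. Within the data shown here, no measured pair swaps cyano for nitro, so neither step bears on this change directly. The nearest guide is the step of a number 14.9 percentage points lower from compound 1 to compound 3 (beyond the scatter), in which cyano arrived on the same aromatic carbon and brought a modest lowering, while the step of a number 8.7 percentage points lower from compound 2 to compound 3 (within the scatter) on the sulfur side stayed within the scatter. Given that the group entering here sits where cyano already stands, and that nothing measured shows a further lowering from that point, the expected step of a number 3.9 percentage points lower from compound 3 to compound 4 (within the scatter) is estimated to stay within the scatter, leaning slightly lower. On this basis compound 4 is expected to give 50%, estimated between 37% and 64%.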

Compound 4, a percentage reported as activity, at one concentration (the size of the read-out at that concentration, not a potency): 76.2%
The estimate for compound 4 lay 26.2 percentage points below the measured number; measured number above the stated range.
By their numbers in this assay, from the lowest: compounds 3, 2, 1 and 4 (each within the scatter of the next, the first and the last beyond it).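

In this assay, this aromatic carbon proves sensitive to the exact group it carries: replacing cyano with nitro gives (a number 22.3 percentage points higher from compound 3 to compound 4 (beyond the scatter)), so the lower number seen with cyano does not extend to nitro. Nitro and methyl, by contrast, cannot be ordered against each other, with (a number 7.4 percentage points higher from compound 1 to compound 4 (within the scatter)), and among the three compounds carrying 1-methyl-1H-tetrazol-5-yl on the sulfur, compound 3 with cyano is the only one that stands apart from both others, its step from the methyl compound being (a number 14.9 percentage points lower from compound 1 to compound 3 (beyond the scatter)). Nothing available accounts for this separation of cyano from nitro and methyl.

Whether cyano and nitro separate in the same way with 4-methyl-4H-1,2,4-triazol-3-yl on the sulfur remains open, as the compounds shown pair that group with cyano alone. Also open, going by these compounds, is where an amine, a methoxy group or a chlorine atom on the same aromatic carbon would fall, and so whether cyano is unusual at this position or merely one of several groups that give a lower number.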